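The source may hold more compounds than are shown below. What is called first, only, known or untested is meant among the compounds shown, and "the series" means these compounds.

Compound 1 `Nc1nc(N)nc(-c2ccccc2Br)n1`: 1.26
Compound 2 `Nc1nc(N)nc(-c2cc(Br)ccc2Br)n1`: 2.09

Among the measured compounds shown here, in a physicochemical assay for lipophilicity (a higher number here means a more lipophilic compound, a lower number a more polar compound), compound 1 gives 1.26, the lower of the two numbers so far; its only measured neighbour is compound 2, which gives 2.09. For the measured compounds named here, the single measured step is a number 0.83 log units higher from compound 1 to compound 2 (beyond the scatter), a bromo in place of hydrogen on an aromatic carbon. Compound 3 `Nc1nc(N)nc(-c2ccccc2Cl)n1` is not yet measured in this assay. It differs from compound 1 by chloro in place of bromo on an aromatic carbon. Going by the values given here, no measured step covers this exchange: the step to compound 2 adds a halogen, it does not trade one for another. The two halogens are both single heavy atoms with no donors or acceptors, so for this assay the expected step is a number 0.16 log units lower from compound 1 to compound 3 (within the scatter), small and downward, within the scatter. Compound 3 is therefore estimated at 1.1, with a range from 0.85 to 1.35.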

Compound 3, partition coefficient: 1.19
The estimate for compound 3 lay 0.09 log units below the measured number; measured number inside the range.
By their numbers in this assay, from the lowest: compounds 3 and 1 (each within the scatter of the next); then compound 2.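

At this position, on an aromatic carbon ortho to a group of 8 heavy atoms, chloro in place of bromo gives a number 0.07 log units lower from compound 1 to compound 3 (within the scatter) in this assay. Among the compounds shown here, the only earlier step, a number 0.83 log units higher from compound 1 to compound 2 (beyond the scatter), added a halogen, whereas this one trades one halogen for another, and by this read-out compound 1 and compound 3 cannot be told apart. Nothing among the results shown offers a reason for this outcome.

The compounds shown leave open whether a group other than bromo or chloro at this same place, such as an amine, a methoxy group or a carboxylic acid, would give a step beyond the scatter. They also leave open whether fluoro or a longer chain there would stay as close to compound 1 as chloro does.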